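The source may report more compounds than this note shows. Statements on the series, on what has been measured and on what is new or still open speak of the compounds shown alone.

Compound 2 `CCOC(=O)C1=Cc2ccccc2OC1(OCc1cn(-c2ccccc2)nn1)C(F)(F)F` is the point of departure. In a functional assay on MCF7 cells (Homo sapiens) for inhibition, read by MTT assay, with a stated time of 24 h (a lower number here means a stronger inhibitor, a higher number a weaker inhibitor), compound 2 gives only a limit, > 150000 nM. Its neighbour compound 1 `CCOC(=O)C1=Cc2ccccc2OC1(OCc1cn(-c2cccc(OC)c2)nn1)C(F)(F)F` carries a methoxy on an aromatic carbon where compound 2 carries hydrogen, and in this assay compound 1 likewise gives only a limit, > 150000 nM. For the measured compounds named here, the single measured step, a step that the two limits leave unreadable from compound 1 to compound 2, therefore has no readable size, and the whole of the evidence amounts to the limit of > 150000 nM in this assay, at which 2 of the 2 values shown sit. Compound 3 `CCOC(=O)C1=Cc2ccccc2OC1(OCc1cn(-c2ccc(F)c(Cl)c2)nn1)C(F)(F)F` differs from compound 2 by 3-chloro-4-fluorophenyl in place of phenyl on an aromatic nitrogen. Going by the values given here, no measured step bears on this change: the one step recorded is unreadable, so the data give no direction for it. In this assay compound 3 is expected to give 150000 nM, within 40000 nM to 150000 nM, most probably again as a limit. The expected step of a number no higher from compound 2 to compound 3 (the limit leaves the size open) is estimated to stay within the scatter.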

Compound 3, half-maximal inhibitory concentration: 25300 nM
For compound 3 the middle estimate is 5.9-fold (0.77 log units) above the measured one; measured number outside the range, below it.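

Replacing phenyl with 3-chloro-4-fluorophenyl on the aromatic nitrogen gives an at least 5.9-fold lower number from compound 2 to compound 3 (0.77 log units; beyond the scatter), which shows that this position can move the number in this assay. Set against the 3-methoxyphenyl group, the same entering group gives an at least 5.9-fold lower number from compound 1 to compound 3 (0.77 log units; beyond the scatter), whereas the step between the two earlier compounds cannot be read. Compound 3 therefore gives the first value in this set that is a number and not a limit, while the other two compounds remain at the ceiling: the limit of > 150000 nM in this assay, at which 2 of the 3 values shown sit.

As far as these compounds go, it remains open whether the chlorine, the fluorine or the two together account for the step; a phenyl carrying chlorine alone or fluorine alone would separate them. Also open, from the compounds shown here alone, is how this assay would read a phenyl carrying an amine or a carboxylic acid at this position.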